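A Smaller Group on the Amide-Type Nitrogen

The source may report more compounds than this note shows. Statements on the series, on what has been measured and on what is new or still open speak of the compounds shown alone.

In a functional assay on the whole organism with Rattus norvegicus as the target (a higher number here means that more compound is needed for the effect, a lower number that less compound is needed), compound 1 `CSc1cc(C)nc(SC)c1NC(=O)N(Cc1cccc(Oc2ccc(Br)cc2)c1)C1CCCCCC1` gives < 0.1 mg/kg, which is a limit and not a number. Going by these compounds, compound 2 `CSc1nc(C)cc(Cl)c1NC(=O)N(Cc1ccc(Oc2ccc(F)cc2)cc1)C1CCCCCC1` gives < 0.1 mg/kg, also a limit, so its exact place is unknown. Compound 3 `Cc1cc(S(C)(=O)=O)c(NC(=O)N(Cc2ccc(Oc3ccc(F)cc3)cc2)C2CCCCCC2)c(S(C)(=O)=O)n1` gives a true number, 0.068 mg/kg.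

Compound 4 `Cc1ccc(NC(=O)N(Cc2ccc(Oc3ccc(F)cc3)cc2)C2CCCCCC2)c(Cl)n1` differs from compound 2 in one place: a group of 8 heavy atoms (6 carbon, 1 nitrogen, 1 chlorine; one six-membered aromatic ring with 1 hetero atom) in place of a group of 10 heavy atoms (7 carbon, 1 nitrogen, 1 sulfur, 1 chlorine; one six-membered aromatic ring with 1 hetero atom), on an amide-type nitrogen. The new group is 2-chloro-6-methylpyridin-3-yl, on an amide-type nitrogen. Among the compounds with values here, compound 3, at 0.068 mg/kg, keeps a larger group at that place, and no measured compound carries one this small. More compound is therefore expected to be needed, by a step beyond the scatter. The estimated change is an at least 4.0-fold higher number from compound 2 to compound 4 (0.60 log units; beyond the scatter). Compound 4 is estimated at 0.4 mg/kg, with an expected range from 0.08 mg/kg to 2 mg/kg.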

Compound 4, dose for half-maximal effect: > 0.1 mg/kg
Compound 4 was reported as a limit; the forecaster's own chance of this, stated with the estimate: 25%; the middle value is on the limit's open side.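

The three earlier compounds all carry larger groups at this place, and the smaller 2-chloro-6-methylpyridin-3-yl on the amide-type nitrogen gives a number no lower from compound 2 to compound 4 (the limit leaves the size open) in this assay. For compound 4, > 0.1 mg/kg is a limit and not a number. The size of the step cannot be read because both compounds sit at limits: the limit of > 0.1 mg/kg in this assay, at which 1 of the 4 values shown sits.

The compounds shown leave open how much more compound 4 needs and which atoms of the larger group matter. Going by these compounds, whether an amine or a methoxy group on the 2-chloro-6-methylpyridin-3-yl group would bring the number back down also remains open.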